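Fluoro for Amino on the Aryl Ring: Compound 4

The compounds below may be only part of what the source reports. "The series", "measured", "known", "first", "only" and "open" are said of these compounds alone.

Measured in an assay on membranes from brain for binding affinity to adenosine receptor A1 (Rattus norvegicus), read by radioligand binding, tested at 20 uM; a lower number here means less inhibition, a higher number more inhibition at the concentration tested (going by the name of the read-out):
compound 1, `Cn1c(=O)[nH]c2c(cnn2-c2ccccc2F)c1=N`, gives 8%;
compound 2, `Cn1c(=O)[nH]c2c(cnn2-c2ccccc2N)c1=N`, gives 0%;
compound 3, `Cn1c(=O)[nH]c2c(cnn2-c2cccc(N)c2)c1=N`, gives 0%.

Compound 1 and compound 2 share a core and differ only by fluoro in place of amino on an aromatic carbon; the measured step is a number 8 percentage points higher from compound 2 to compound 1 (within the scatter). Compound 3 has the same atoms as compound 2, joined differently; the difference between the two cores is not broken down here. Compound 4, `Cn1c(=O)[nH]c2c(cnn2-c2cccc(F)c2)c1=N`, is not yet measured and differs from compound 3 by fluoro in place of amino on an aromatic carbon. The place is not the same: in compound 1 the fluoro sits ortho to a large group, in compound 4 meta to a large group, so this is the same kind of change, not the same change. Going by the values given here, a similar small step is expected from compound 3 to compound 4, namely a number 4 percentage points higher from compound 3 to compound 4 (within the scatter), resting on the one measured instance of this kind of change, a number 8 percentage points higher from compound 2 to compound 1 (within the scatter), and on compound 3 giving 0%. For compound 4 an inhibition of 4% is expected, likely between -6% and 15%.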

Compound 4, a percentage reported as inhibition, at one concentration (the size of the read-out at that concentration, not a potency): 44%
Compound 4: the middle estimate sits 40 percentage points below what was measured; the measured number lies above the stated range.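

In this assay, fluoro in place of amino on an aromatic carbon gives a number 44 percentage points higher from compound 3 to compound 4 (beyond the scatter). This change therefore does not carry over at a fixed size from one core to another in this series: the same change on two cores in this assay, a number 8 percentage points higher (within the scatter) from compound 2 to compound 1 and a number 44 percentage points higher (beyond the scatter) from compound 3 to compound 4, 36 percentage points apart, beyond the scatter of two such steps
These two pairs do not show why the steps differ, and since the fluoro also sits in a different place on the ring in compound 1 and compound 4, they give no rule for predicting the step on a further core.

Going by these compounds, it remains open how a chloro, methyl or methoxy group would compare with fluoro when meta to a large group. On these data alone, whether compound 4 also acts on other adenosine receptors remains open too.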